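Cytotoxicity check across the series: compound 1 to compound 4

This account rests on a few compounds, and the source may have more. Where it says the series, first, only, none or still open, it means among the compounds named here.

The series is followed in an ADME assay on HCT-116 cells (Homo sapiens) for cytotoxicity, read by CellTiter-Glo, with a stated time of 72 h; a lower number here means a stronger inhibitor, a higher number a weaker inhibitor. Compound 1 `COc1ccccc1-c1cccc(S(=O)(=O)N2CCC(N3CCC(C)CC3)CC2)c1` is the reference point. In this assay compound 1 gives > 5000 nM, which is a limit of the assay and not a number. Compound 2 `CC1CCCN(C2CCN(S(=O)(=O)c3ccc(OC(F)F)cc3)CC2)C1` likewise returns a limit in this assay, > 5000 nM. Compound 3 `Cc1ccc(S(=O)(=O)N2CCC(N3CCC(C)CC3)CC2)cc1C` gives > 5000 nM in this assay, again a limit. Where compound 1 stands can thus be told only as a limit: the limit of > 5000 nM in this assay, at which 3 of the 3 values shown sit. Going by the values given here, none of the three values is a number, so the three compounds cannot be ordered among themselves, and no step between measured compounds can be computed.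

The next compound, compound 4 `CC1CCN(C2CCN(S(=O)(=O)c3cccc(-c4ccc5ccccc5c4)c3)CC2)CC1`, differs from compound 1 in one place: naphthalen-2-yl in place of 2-methoxyphenyl on an aromatic carbon. Among the compounds with values here, with every measured compound sitting at the limit, there is no measured step to rest an expectation on; the working assumption is no step beyond the scatter, in either direction. The expected step that the limit leaves unreadable from compound 1 to compound 4 is therefore estimated as small against the scatter. Compound 4 is expected to give about 8000 nM in this assay, with a range estimated from 3000 nM to 30000 nM, most likely reported again as a limit rather than a number.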

Compound 4, half-maximal inhibitory concentration: > 5000 nM
Compound 4 was reported as a limit; the forecaster's own chance of this, stated with the estimate: 75%; the middle value lies beyond the limit too.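

No step can be read from compound 1 to compound 4, with naphthalen-2-yl in place of 2-methoxyphenyl, as both results in this assay are limits and not numbers: the limit of > 5000 nM in this assay, at which 4 of the 4 values shown sit.

The compounds shown leave open how far each lies beyond that limit, and whether any change to the shared core would give a readable value.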